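Lengthening the Acid Chain of Compound 2

The compounds below may be only part of what the source reports. "The series", "measured", "known", "first", "only" and "open" are said of these compounds alone.

Compound 1, `CCCCOc1cccc(C(=O)n2c(C)c(CC(=O)O)c3cc(OC)ccc32)c1`: 1700 nM
Compound 2, `CCCCOc1ccc(C(=O)n2c(C)c(CC(=O)O)c3cc(OC)ccc32)cc1`: 4700 nM
Compound 3, `CCCCOc1ccc(C(=O)n2c(CCC)c(C(=O)O)c3cc(OC)ccc32)cc1`: 2900 nM

In an assay on isolated protein for binding affinity to prostaglandin E2 receptor EP2 subtype (Mus musculus) (a higher number here means a weaker inhibitor, a lower number a stronger inhibitor), compound 2 gives 4700 nM, the highest of the three numbers. Compound 3 gives 2900 nM, which lies within the usual scatter of the number for compound 2, so the two cannot be told apart. Compound 1 gives 1700 nM, a lower number that lies beyond the scatter.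

Compound 4, `CCCCOc1ccc(C(=O)n2c(C)c(CCCCC(=O)O)c3cc(OC)ccc32)cc1`, differs from compound 2 in one place: 3-carboxypropyl in place of carboxy on a saturated chain carbon bound to an aromatic carbon. Among the measured compounds shown here, no measured pair shows what this kind of lengthening does here, so the direction cannot be read from the data. The step of a 1.2-fold lower number from compound 2 to compound 4 (0.07 log units; within the scatter) is therefore expected to be none beyond the scatter, with wide uncertainty. Compound 4 is estimated to give 4000 nM, in a range from 1000 nM to 16000 nM.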

Compound 4, inhibition constant: 5200 nM
The estimate for compound 4 lay 1.3-fold (0.11 log units) below the measured number; low and high end bracket the measured number.
By their numbers in this assay, from the lowest: compounds 1, 3, 2 and 4 (each within the scatter of the next, the first and the last beyond it).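

Putting 3-carboxypropyl in place of carboxy on a saturated chain carbon bound to an aromatic carbon gives a 1.1-fold higher number from compound 2 to compound 4 (0.04 log units; within the scatter) in this assay. Among the compounds shown here, this is the first comparison here that changes only one place, and it shows that this position takes the longer acid chain with no change beyond the scatter. No measurement available here explains this result.

On these data alone, whether an amine or an amide at the end of this chain would leave the number as it stands remains open. So does whether the longer chain would behave alike on compound 1.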